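A Side-Chain Exchange From One Measured Compound

The source may hold more compounds than are shown below. What is called first, only, known or untested is meant among the compounds shown, and "the series" means these compounds.

Among the measured compounds shown here, in a functional assay on A549 cells (Homo sapiens) for cytotoxicity, read by MTT assay, with a stated time of 48 h (on this read-out lower numbers stand for stronger inhibition and higher numbers for weaker inhibition), compound 1 (`COc1c(OCCCCNCc2ccccc2)cc(O)c2c(=O)cc(-c3ccccc3)oc12`) gives 4590 nM and this is the only number available, so it cannot yet be ranked against any other compound. For compound 2 (`CC(C)NCCCCOc1c(O)cc(O)c2c(=O)cc(-c3ccccc3)oc12`) the entry is "not determined" (no result reported) and it therefore offers no comparison. Compound 3 (`COc1c(OCCCN2CCN(C)CC2)cc(O)c2c(=O)cc(-c3ccccc3)oc12`) keeps the core of compound 1 but carries 4-methylpiperazin-1-yl in place of (benzylamino)methyl on a saturated chain carbon, three bonds along the chain from an oxygen on an aromatic ring. The one six-membered aromatic ring of carbon only leaves with the old group, and a six-membered non-aromatic ring with 2 hetero atoms enters. For the measured compounds named here, no measured pair shows what such an exchange does in this assay and any forecast must therefore stay broad. The expected change is a 1.5-fold higher number from compound 1 to compound 3 (0.18 log units; within the scatter) and it leans slightly toward weaker inhibition, with no step beyond the usual scatter firmly expected. For compound 3 the estimated value is 7000 nM with 2000 nM to 25000 nM as its expected range.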

Compound 3, half-maximal inhibitory concentration: 9900 nM
Beside the measured number, compound 3's estimate is 1.4-fold (0.15 log units) below it; the range from low to high includes it.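

In this assay, among the compounds shown here, putting 4-methylpiperazin-1-yl in place of (benzylamino)methyl on a saturated chain carbon, three bonds along the chain from an oxygen on an aromatic ring, gives a 2.2-fold higher number from compound 1 to compound 3 (0.33 log units; beyond the scatter), the first measured step at this position, and it runs toward weaker inhibition. The step is modest, but it shows that the read-out responds to an exchange at this place, and that compound 3 , which has lost the six-membered aromatic ring of carbon only, still gives a measured 9900 nM on the same scale. No measurement at hand says why the number moves.

From the compounds shown here alone, this one step cannot separate the departure of the aromatic ring from the change in the nitrogen group, so it stays open whether a morpholin-4-yl ring, a piperidin-1-yl ring or a simple dimethylamino group at the same place would read closer to compound 1 or to compound 3. The compounds shown also leave open whether the step would hold on a longer chain, or whether a benzyl group placed on the piperazine ring would restore the number of compound 1.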